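The source may hold more compounds than are shown below. What is called first, only, known or untested is meant among the compounds shown, and "the series" means these compounds.

Compound 3 `Cn1c(=O)cnn(CCCCN2CCN(c3ccc(F)cn3)CC2)c1=O` stands at the edge of what has been measured: in an assay for displacement of a labelled ligand from Adrenergic receptor alpha-1 (Homo sapiens) (a lower number here means a stronger inhibitor, a higher number a weaker inhibitor), compound 3 gives > 10000 nM, which is a limit rather than a number (the limit of > 10000 nM in this assay, at which 1 of the 3 values shown sits). Compound 1 `Cn1c(=O)cnn(CCCCN2CCN(c3c(Br)cccc3C#N)CC2)c1=O` gives 450 nM in this assay, and compound 2 `Cn1c(=O)cnn(CCCCN2CCN(c3ccccn3)CC2)c1=O` gives 262 nM. The steps of an at least 22-fold higher number from compound 1 to compound 3 (1.34 log units; beyond the scatter) and an at least 38-fold higher number from compound 2 to compound 3 (1.58 log units; beyond the scatter) are both large and set compound 3 apart, whereas the step of a 1.7-fold lower number from compound 1 to compound 2 (0.23 log units; within the scatter) lies within the scatter. Compound 4 `Cn1c(=O)cnn(CCCCN2CCN(c3cccc(F)n3)CC2)c1=O` differs from compound 3 by 6-fluoropyridin-2-yl in place of 5-fluoropyridin-2-yl on an amine nitrogen in a ring. For the measured compounds named here, no measured pair shows a fluoropyridin-2-yl against another fluoropyridin-2-yl, so the expected step of an at least 2.0-fold lower number from compound 3 to compound 4 (0.30 log units; that floor lies within the scatter) rests on the standing of compound 3 alone. Compound 4 is expected near 5000 nM in this assay, estimated between 800 nM and 30000 nM, with a real chance of another limit.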

Compound 4, inhibition constant: > 10000 nM
Compound 4 was reported as a limit; the forecaster's own chance of this, stated with the estimate: 50%; middle value at least 2.0-fold (0.30 log units) from the limit.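

Fluoro in place of hydrogen on an aromatic carbon now gives a large step in 6-fluoropyridin-2-yl as well as in 5-fluoropyridin-2-yl, with an at least 38-fold higher number from compound 2 to compound 4 (1.58 log units; beyond the scatter). Against the 2-bromo-6-cyanophenyl compound the result is also large, with an at least 22-fold higher number from compound 1 to compound 4 (1.34 log units; beyond the scatter). Compound 3 and compound 4 are both limits in this assay, so the step between them cannot be read and gives no order for the two fluoropyridin-2-yl groups: the limit of > 10000 nM in this assay, at which 2 of the 4 values shown sit.

Still open, on these data alone, is whether a chloro or methyl group on the pyridin-2-yl ring gives the same loss as fluoro. As far as these compounds go, how far the true values of compound 3 and compound 4 lie past their limits also remains unknown.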